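A Cationic Chain in Place of a Hydroxy Group

The source may hold more compounds than are shown below. What is called first, only, known or untested is meant among the compounds shown, and "the series" means these compounds.

Within the data shown here, compound 2 `O=c1c(OCCO)c(-c2ccc(O)c(O)c2)oc2ccccc12` gives 600 nM in a functional assay for inhibition, with Rattus norvegicus as the target, using microsomes (on this read-out higher numbers stand for weaker inhibition and lower numbers for stronger inhibition), the lowest of the two numbers measured so far. Compound 1 `O=c1cc(-c2ccc(O)c(O)c2)oc2cc(OCCO)ccc12` gives 16400 nM in this assay, a far higher number than compound 2. Compound 3 `C[N+](C)(C)CCCCCCCCOc1c(-c2ccc(O)c(O)c2)oc2ccccc2c1=O` remains to be measured in this assay. It differs from compound 2 by a group of 10 heavy atoms (9 carbon, 1 nitrogen; no ring) in place of one oxygen atom, on a saturated chain carbon, two bonds along the chain from an oxygen on an aromatic ring. Among the measured compounds shown here, no step between measured compounds is available to guide the size of this change. The step of a 2.0-fold higher number from compound 2 to compound 3 (0.30 log units; within the scatter) is expected to be a modest weakening, perhaps no further than the usual scatter. Compound 3 is estimated at 1200 nM, with a range from 250 nM to 6000 nM.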

Compound 3, half-maximal inhibitory concentration: 1000 nM
Beside the measured number, compound 3's estimate is 1.2-fold (0.08 log units) above it, within the range that was stated.
By their numbers in this assay, from the lowest: compounds 2 and 3 (each within the scatter of the next); then compound 1.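

In this assay, the step of a 1.7-fold higher number from compound 2 to compound 3 (0.22 log units; within the scatter) lies within the scatter, so this place on the saturated chain carbon accepts the group of 10 heavy atoms with net charge +1 in place of the hydroxy without a readable loss. The earlier compounds shown here, which both carry the hydroxy, could not show this tolerance. No measurement given here explains it. From the compounds shown here alone, it remains open whether a shorter chain ending in the same group, or a chain of this length ending in a primary amine or a carboxylic acid, would read alike.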